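Swapping the aryl on the sulfonyl: does the earlier gain repeat?

The source may report more compounds than this note shows. Statements on the series, on what has been measured and on what is new or still open speak of the compounds shown alone.

Compound 1 `C=C(CC)C(=O)c1ccc(OCC(=O)NCCNS(=O)(=O)c2cc(Cl)ccc2OC)c(Cl)c1Cl` is built from a common core joined through an amide to a chain that ends in a sulfonamide. In a functional assay on HL-60 cells (Homo sapiens) for cytotoxicity, read by luminescence (a higher number here means a weaker inhibitor, a lower number a stronger inhibitor), compound 1 gives 1600 nM. Compound 2 `C=C(CC)C(=O)c1ccc(OCC(=O)NCCNS(=O)(=O)c2ccc([N+](=O)[O-])cc2)c(Cl)c1Cl` keeps everything but the ring on the sulfonyl sulfur, the change being (4-nitrophenyl in place of 5-chloro-2-methoxyphenyl on a sulfonyl sulfur), and in this assay compound 2 gives 580 nM; the step is a 2.8-fold lower number from compound 1 to compound 2 (0.44 log units; beyond the scatter).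

Compound 3 `C=C(CC)C(=O)c1ccc(OCC(=O)N2CCN(S(=O)(=O)c3cc(Cl)ccc3OC)CC2)c(Cl)c1Cl` has the same core and the same sulfonyl ring as compound 1 but a different linking piece; how the two cores differ is not broken down here. In this assay compound 3 gives 1410 nM, which lies within the scatter of compound 1.

Compound 4 `C=C(CC)C(=O)c1ccc(OCC(=O)N2CCN(S(=O)(=O)c3ccc([N+](=O)[O-])cc3)CC2)c(Cl)c1Cl` is not yet measured. It differs from compound 3 by 4-nitrophenyl in place of 5-chloro-2-methoxyphenyl on a sulfonyl sulfur. The surroundings are not identical: in compound 1 the sulfonyl sulfur also carries a sulfonamide nitrogen, in compound 3 a sulfonamide nitrogen in a ring, so this is the same kind of change rather than the same one.

In this assay the expected step is a 2.6-fold lower number from compound 3 to compound 4 (0.41 log units; beyond the scatter). This expectation rests on the step of a 2.8-fold lower number from compound 1 to compound 2 (0.44 log units; beyond the scatter). For compound 4 the estimate in this assay is 550 nM, with a range from 250 nM to 1200 nM.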

Compound 4, half-maximal inhibitory concentration: 3260 nM
For compound 4 the middle estimate is 5.9-fold (0.77 log units) below the measured one, outside the stated range (above it).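

In this assay the same swap to 4-nitrophenyl now runs the opposite way, with a 2.3-fold higher number from compound 3 to compound 4 (0.36 log units; beyond the scatter), so here it yields a weaker inhibitor rather than a stronger one. The gain seen on the core of compound 1 therefore does not carry over to the core of compound 3, and the two steps differ in direction as well as in number: the same change on two cores in this assay, a 2.8-fold lower number (0.44 log units; beyond the scatter) from compound 1 to compound 2 and a 2.3-fold higher number (0.36 log units; beyond the scatter) from compound 3 to compound 4, 6.4-fold (0.80 log units) apart, beyond the scatter of two such steps

For the compounds shown here, this does not show why the two cores respond differently, and with only two pairs it gives no general rule for either core, only a warning that a step measured on one core cannot simply be added to another.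

Each core is shown with only two sulfonyl rings, so it remains open whether a plain phenyl ring, or a ring carrying only the chlorine or only the methoxy group, would behave differently on the two cores. From the compounds shown here alone, it also remains open how the swap would behave with a longer chain as the linking piece.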